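The source may hold more compounds than are shown below. What is called first, only, known or untested is meant among the compounds shown, and "the series" means these compounds.

Measured so far:
- compound 1, `COc1cc(Oc2ccc(NC(=O)Nc3cccc(C(F)(F)F)c3)cc2)ncn1`: 4000 nM
- compound 2, `CC(C)Nc1cc(Oc2ccc(NC(=O)Nc3cccc(C(F)(F)F)c3)cc2)ncn1`: 40 nM

Compound 1 and compound 2 share one core and differ only in the group on the ring at its far end. In an assay on isolated protein for inhibition of serine/threonine-protein kinase TNNI3K (Homo sapiens) (a lower number here means a stronger inhibitor, a higher number a weaker inhibitor), compound 1 gives 4000 nM, and compound 2 gives 40 nM. The step is a 100-fold lower number from compound 1 to compound 2 (2.00 log units; beyond the scatter). Compound 2 thus stands lowest of the two numbers, and the nearest measured compound, compound 1, sits well apart from it.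

Compound 3, `CC(=O)Nc1cc(Oc2ccc(NC(=O)Nc3cccc(C(F)(F)F)c3)cc2)ncn1`, has not been measured. Its change from compound 2 is acetyl in place of isopropyl on a nitrogen on an aromatic ring. Among the compounds with values here, the one measured step concerns a different exchange, methoxy for isopropylamino, so it bears on this step only loosely: it shows that what sits at this place can move the number a great deal. Compound 3 keeps the nitrogen of compound 2 but not the isopropyl, so a weakening step, a 13-fold higher number from compound 2 to compound 3 (1.10 log units; beyond the scatter), is expected. The estimate for compound 3 in this assay is 500 nM, with a range from 80 nM to 3000 nM.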

Compound 3, half-maximal inhibitory concentration: 20 nM
Beside the measured number, compound 3's estimate is 25-fold (1.40 log units) above it; measured number below the stated range.
By their numbers in this assay, from the lowest: compounds 3 and 2 (each within the scatter of the next); then compound 1.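

Acetyl in place of isopropyl on the nitrogen gives a 2.0-fold lower number from compound 2 to compound 3 (0.30 log units; within the scatter) in this assay, so a branched carbon group is not required at this nitrogen: an acetyl, with its carbonyl and 1 hydrogen-bond acceptor, gives a number that cannot be told apart from that of isopropyl. Acetamido in place of methoxy gives a 200-fold lower number from compound 1 to compound 3 (2.30 log units; beyond the scatter), so among these three compounds, both groups attached through nitrogen stand far from the one attached through oxygen. No evidence at hand explains why two such different groups on this nitrogen give matching numbers.

On these data alone, what remains open is whether a plain amine, with nothing on the nitrogen, would keep the number this low. Also open, as far as these compounds go, is how much room there is on this nitrogen for a longer chain, such as butyryl, or for a ring, such as cyclopropanecarbonyl.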